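The source may hold more compounds than are shown below. What is called first, only, known or untested is meant among the compounds shown, and "the series" means these compounds.

Measured so far:
- compound 1, `Cc1ccc(NC(=O)N[C@H](C)c2ccccc2)cc1`: 98%
- compound 2, `CCc1ccc(NC(=O)N[C@H](C)c2ccccc2)cc1`: 47%
- compound 3, `CC(C)c1ccc(NC(=O)N[C@H](C)c2ccccc2)cc1`: 79%

Compound 3 stands second highest of the three numbers in an ADME assay on the whole organism with Oryza sativa as the target, tested at 1 uM; a higher number here means a weaker effect of the compound at the concentration tested, a lower number a stronger effect: compound 1 is nearest, and a number 19 percentage points lower from compound 1 to compound 3 (beyond the scatter) shows the gap; compound 2 is furthest, and a number 32 percentage points higher from compound 2 to compound 3 (beyond the scatter) shows that gap. The largest step in the set, a number 51 percentage points lower from compound 1 to compound 2 (beyond the scatter), shows how strongly the number can move within this small series.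

Compound 4, `CCCc1ccc(NC(=O)N[C@H](C)c2ccccc2)cc1`, is not yet measured. Its relation to compound 3 is propyl in place of isopropyl on an aromatic carbon. Among the compounds with values here, no measured pair shows a branched group against a straight one of the same size, so the bearing steps are indirect. The two steps that build up the larger chains, a number 19 percentage points lower from compound 1 to compound 3 (beyond the scatter) and a number 32 percentage points higher from compound 2 to compound 3 (beyond the scatter), point in opposite directions and are of modest to large size, and the one from the methyl to the ethyl, a number 51 percentage points lower from compound 1 to compound 2 (beyond the scatter), is large. A sizeable step in either direction is therefore possible. The expectation is that compound 4 falls between the numbers of compound 2 and compound 3, closer to the latter, so that the estimated step is a number 14 percentage points lower from compound 3 to compound 4 (beyond the scatter). The estimate for compound 4 is thus 65%, with a range from 40% to 90%.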

Compound 4, a percentage reported as activity, at one concentration (the size of the read-out at that concentration, not a potency): 31%
Compound 4: middle estimate off by 34 percentage points, on the high side, and the stated range ends above it.
By their numbers in this assay, from the lowest: compound 4; then compound 2; then compound 3; then compound 1.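

In this assay, within the data shown here, the first pair with a branched and a straight group of the same size on this aromatic carbon, para to a large group, gives a number 48 percentage points lower from compound 3 to compound 4 (beyond the scatter); the two compounds have the same atoms, so how the three carbons are joined is enough to move the number, and by more than the scatter. Along the straight chains the number keeps falling, with a number 51 percentage points lower from compound 1 to compound 2 (beyond the scatter), then a number 16 percentage points lower from compound 2 to compound 4 (beyond the scatter), and overall a number 67 percentage points lower from compound 1 to compound 4 (beyond the scatter), which leaves the propyl compound with the lowest number of the four and the strongest effect at the concentration tested, while the branched compound 3 goes against this trend of a falling number with a larger group. No measurement of any other kind bears on these differences, so the data assign them no explanation.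

On these data alone, whether the fall continues with a longer chain such as butyl or pentyl, or turns back, remains open, and so does whether a second branched group such as tert-butyl or cyclopropyl would sit nearer compound 3 or compound 4. Also open, as far as these compounds go, is how a methoxy group or a chlorine atom at this place would compare with the propyl of compound 4.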